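Replacing the Ring on Nitrogen in a Weak Series

The source may hold more compounds than are shown below. What is called first, only, known or untested is meant among the compounds shown, and "the series" means these compounds.

In a functional assay on MDA-MB-468 cells (Homo sapiens) for antiproliferative activity, read by MTT assay, with a stated time of 72 h (on this read-out lower numbers stand for stronger inhibition and higher numbers for weaker inhibition), compound 1 `CCCCCn1ccnc1-c1cc(OC)c(OC)c(OC)c1` gives 57900 nM, compound 2 `COc1cc(-c2nccn2-c2cccc(C)c2)cc(OC)c1OC` gives 22600 nM and compound 3 `COc1cccc(-n2ccnc2-c2cc(OC)c(OC)c(OC)c2)c1` gives 10400 nM. Compound 3 therefore has the lowest number and is the most potent of the three, though only by modest margins. The next compound, compound 4 `COc1cc(-c2nccn2-c2ccc(F)cc2)cc(OC)c1OC`, has 4-fluorophenyl in place of the 3-methoxyphenyl of compound 3 on an aromatic nitrogen: 4-fluorophenyl in place of 3-methoxyphenyl on an aromatic nitrogen.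

Two kinds of measured step bear on this swap. Putting a substituted phenyl ring where pentyl stood lowered the number, giving a 2.6-fold lower number from compound 1 to compound 2 (0.41 log units; beyond the scatter) with 3-methylphenyl and a 5.6-fold lower number from compound 1 to compound 3 (0.75 log units; beyond the scatter) with 3-methoxyphenyl. Changing methyl to methoxy on that ring gave a 2.2-fold lower number from compound 2 to compound 3 (0.34 log units; beyond the scatter), so changes on the ring itself have so far moved the number only a little. Within the data shown here, no measured compound carries 4-fluorophenyl, so this comparison is indirect. Compound 4 keeps a phenyl ring on that nitrogen but loses the methoxy, and compound 2, which also lacks it, gives 22600 nM. The expected step is small, a 1.5-fold higher number from compound 3 to compound 4 (0.19 log units; within the scatter), with a slightly higher number the likelier direction. For compound 4 the estimated value is 16000 nM, with an expected range from 5000 nM to 45000 nM.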

Compound 4, half-maximal inhibitory concentration: 62200 nM
The estimate for compound 4 lay 3.9-fold (0.59 log units) below the measured number; measured number outside the range, above it.
By their numbers in this assay, from the lowest: compound 3; then compound 2; then compounds 1 and 4 (each within the scatter of the next).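

In this assay, a phenyl ring on this nitrogen does not by itself lower the number: swapping pentyl for 4-fluorophenyl gives a 1.1-fold higher number from compound 1 to compound 4 (0.03 log units; within the scatter), so compound 4 goes against the trend set by compound 2 and compound 3. The choice of ring matters more than the earlier methyl-to-methoxy step, a 2.2-fold lower number from compound 2 to compound 3 (0.34 log units; beyond the scatter), suggested, with a 6.0-fold higher number from compound 3 to compound 4 (0.78 log units; beyond the scatter) and a 2.8-fold higher number from compound 2 to compound 4 (0.44 log units; beyond the scatter) marking the loss on moving to 4-fluorophenyl. Nothing in the available data explains this loss.

3-Methoxyphenyl and 4-fluorophenyl differ both in the group carried and in where it sits on the ring, and the compounds shown cannot separate these two changes. Going by these compounds, it also remains open whether plain phenyl, or a phenyl ring carrying an amine, would give a number nearer that of compound 3 or that of compound 4.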